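The source may hold more compounds than are shown below. What is called first, only, known or untested is meant among the compounds shown, and "the series" means these compounds.

In an ADME assay on HUVEC cells (Homo sapiens) for antiproliferative activity, read by MTT assay, with a stated time of 48 h (on this read-out lower numbers stand for stronger inhibition and higher numbers for weaker inhibition), compound 3 `N#CC1=C(N)Oc2c(N)cc3nc4ccccc4nc3c2C12C(=O)N(Cc1cnnn1-c1c(F)cccc1F)c1ccccc12` reaches only a limit of the assay, > 50000 nM. Compound 1 `Cc1ccccc1-n1nncc1CN1C(=O)C2(C(C#N)=C(N)Oc3c(N)cc4nc5ccccc5nc4c32)c2ccccc21` also stops at a limit in this assay, > 50000 nM. Among the measured compounds shown here, compound 2 `N#CC1=C(N)Oc2c(N)cc3nc4ccccc4nc3c2C12C(=O)N(Cc1cnnn1-c1ccccc1Br)c1ccccc12` is the one member of the set with a number: in this assay compound 2 gives 34200 nM. One step is an at least 1.4-fold lower number from compound 1 to compound 2 (0.16 log units; that floor lies within the scatter), with bromo in place of methyl on an aromatic carbon; another is an at least 1.4-fold higher number from compound 2 to compound 3 (0.16 log units; that floor lies within the scatter), with 2,6-difluorophenyl in place of 2-bromophenyl on an aromatic nitrogen; the third is a step that the two limits leave unreadable from compound 1 to compound 3. For the measured compounds named here, because of the limit of > 50000 nM in this assay, at which 2 of the 3 values shown sit, no step in this set can be read beyond the scatter.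

Compound 4 `N#CC1=C(N)Oc2c(N)cc3nc4ccccc4nc3c2C12C(=O)N(Cc1cnnn1-c1ccc(Cl)cc1Cl)c1ccccc12` differs from compound 3 by 2,4-dichlorophenyl in place of 2,6-difluorophenyl on an aromatic nitrogen of a five-membered aromatic ring with 3 nitrogen. Going by the values given here, the steps that bear on this change are the two that exchange the group on that aromatic nitrogen, and neither yields a readable size; the only number in the set, from compound 2, stands close to the limit. No movement beyond the scatter in this assay is therefore expected, and the expected step is an at least 1.1-fold lower number from compound 3 to compound 4 (0.04 log units; that floor lies within the scatter). Compound 4 is estimated at 45000 nM, with a range from 20000 nM to 100000 nM.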

Compound 4, half-maximal inhibitory concentration: > 50000 nM
Compound 4: a limit, no number; the forecaster's own chance of this, stated with the estimate: 55%; middle value at least 1.1-fold (0.04 log units) from the limit.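

In this assay compound 4, with 2,4-dichlorophenyl on the aromatic nitrogen, also stops at a limit of the assay, as compound 1 and compound 3 do, so the steps among these three compounds cannot be read. Among the compounds shown here, the one step that can be read is an at least 1.4-fold higher number from compound 2 to compound 4 (0.16 log units; that floor lies within the scatter), so replacing 2-bromophenyl with 2,4-dichlorophenyl shows no movement beyond the scatter, and compound 2 remains the only one of the four phenyl-bearing compounds with a number. The size of this change at this position therefore stays unknown because the values crowd at one limit: the limit of > 50000 nM in this assay, at which 3 of the 4 values shown sit.

What the compounds shown leave open is whether any group on this aromatic nitrogen can bring the number clearly below that limit, since all four carry a substituted phenyl group there. From the compounds shown here alone, an amine or a carboxylic acid on that phenyl group, or a longer alkyl chain in its place, could test this, and the effect of changes elsewhere on the shared core also remains open.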